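The compounds below may be only part of what the source reports. "The series", "measured", "known", "first", "only" and "open" are said of these compounds alone.

In a physicochemical assay for lipophilicity, at pH 7.4 (on this read-out lower numbers stand for lower lipophilicity and higher numbers for higher lipophilicity), compound 1 `CNC(=O)c1cc(C(=O)N[C@H]2[C@@H]3COC[C@@H]32)cc2c1OC[C@H]2c1cccc(OC)c1` gives 3.2 and compound 2 `CCC(=O)N1C[C@@H]2[C@H](C1)[C@H]2NC(=O)c1cc(C(=O)NC)c2c(c1)[C@H](c1ccccc1)CO2` gives 3.4, so the two lie within the usual scatter of each other. Compound 3 `CNC(=O)c1cc(C(=O)NCCC[C@H]2OC[C@H](N)CO2)cc2c1OC[C@H]2c1ccccc1` differs from compound 2 on an amide-type nitrogen: a group of 10 heavy atoms (7 carbon, 1 nitrogen, 2 oxygen; one six-membered non-aromatic ring with 2 hetero atoms) in place of a group of 10 heavy atoms (8 carbon, 1 nitrogen, 1 oxygen; one three-membered non-aromatic ring of carbon only, one five-membered non-aromatic ring with 1 hetero atom), on an amide-type nitrogen. Among the compounds with values here, no measured pair differing in one place is available to size this swap, so any expectation is rough. Starting from compound 2 at 3.4, a clear fall in this assay, beyond the scatter, is expected from the hydrogen-bond counts of the swap. The expected change is a number 1.30 log units lower from compound 2 to compound 3 (beyond the scatter). For compound 3 the estimate is 2.1, with an expected range from 1.3 to 2.9.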

Compound 3, distribution coefficient: 2.6
Compound 3: the middle estimate sits 0.50 log units below what was measured, within the range that was stated.
By their numbers in this assay, from the lowest: compound 3; then compounds 1 and 2 (each within the scatter of the next).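

On the amide-type nitrogen, the group can shift the number in this assay clearly, even at an equal 10 heavy atoms: the swap gives a number 0.80 log units lower from compound 2 to compound 3 (beyond the scatter). The entering group has 1 hydrogen-bond donor and 3 hydrogen-bond acceptors, against 0 and 1 in the group that leaves. No measurement here gives a reason for this fall.

The swap changes the rings and the hydrogen-bond counts together, and the compounds shown cannot separate the two. Where a carboxylic acid on this nitrogen would fall also stays open.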